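Compound 3: same atoms, fewer drawn stereocentres

The source may report more compounds than this note shows. Statements on the series, on what has been measured and on what is new or still open speak of the compounds shown alone.

Measured so far in an ADME assay on microsomes from liver (Homo sapiens) for pharmacokinetics; on this read-out lower numbers stand for slow clearance and higher numbers for fast clearance:
- compound 1 `C[C@@H]1C[C@H]1C(=O)N1CCN(c2nc(-c3cnn(C)c3)ncc2C#N)C[C@H]1C` reads < 16 mL/min/kg as a limit
- compound 2 `C[C@@H]1CN(c2cnc(C#N)c(-c3cnn(C)c3)n2)CCN1C(=O)C1CC1` reads < 16 mL/min/kg as a limit

Compound 1 stands at < 16 mL/min/kg in this assay, and that reading is a limit of the assay and not a number. Compound 2 reads < 16 mL/min/kg, which is also a limit. All that is known so far is the limit of < 16 mL/min/kg in this assay, at which 2 of the 2 values shown sit, and nothing finer.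

Compound 3 `CC1CC1C(=O)N1CCN(c2nc(-c3cnn(C)c3)ncc2C#N)C[C@H]1C` has the same atoms and bonds as compound 1. The difference lies only in the drawing, (the two compounds have the same atoms and bonds; at least one stereo element is drawn with a configuration in one of them and without one in the other: 2 of 3 stereo elements differ; a stereocentre at a saturated ring carbon is drawn R in compound 1 and without a configuration in compound 3; a stereocentre at a saturated ring carbon is drawn R in compound 1 and without a configuration in compound 3), so two stereocentres at saturated ring carbons drawn R in compound 1 are drawn without a configuration in compound 3.

Among the compounds with values here, no measured pair shows what such a difference does in this assay, so no step beyond the scatter is expected, in either direction. This expectation rests on compound 1 at < 16 mL/min/kg as a limit. The estimated change is a step that the limit leaves unreadable from compound 1 to compound 3 in size. Compound 3 is expected at 12 mL/min/kg, with an estimated range from 7 mL/min/kg to 24 mL/min/kg and no firmer figure yet.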

Compound 3, clearance: < 16 mL/min/kg
Compound 3: only a limit was reported; the forecaster's own chance of this, stated with the estimate: 70%; the middle value does not contradict the limit.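

In this assay compound 3 gives < 16 mL/min/kg, which is a limit of the assay and not a number. Compound 1 also stands at a limit, so no step between compound 1 and compound 3 can be read: the limit of < 16 mL/min/kg in this assay, at which 3 of the 3 values shown sit. The compounds shown leave open where each truly lies under that limit, and whether the two stereocentres drawn without a configuration in compound 3 matter for clearance: the fact that one of compounds 1 and 3 is drawn with a defined configuration and the other without, at the place where they differ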